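Adding one methoxy: a measured step and an expected one

The source may report more compounds than this note shows. Statements on the series, on what has been measured and on what is new or still open speak of the compounds shown alone.

compound 1 `COc1cc(C(=O)c2sc(Nc3ccccc3)nc2N)cc(OC)c1OC`: 23 nM
compound 2 `COc1ccc(C(=O)c2sc(Nc3ccccc3)nc2N)cc1OC`: > 10000 nM
compound 3 `Nc1nc(Nc2ccc(F)cc2)sc1C(=O)c1ccccc1`: > 10000 nM

In a functional assay on FM3A cells (Mus musculus) for antiproliferative activity, read by cell counting, with a stated time of 2 days (a higher number here means a weaker inhibitor, a lower number a stronger inhibitor), compound 1 gives 23 nM. For compound 2 the value in this assay is a limit of the assay, > 10000 nM. For compound 3 the value in this assay is likewise a limit, > 10000 nM. Compound 1 arises from compound 2 by methoxy in place of hydrogen on an aromatic carbon, a change that gave an at least 430-fold lower number from compound 2 to compound 1 (2.63 log units; beyond the scatter). Two of the three values sit at the limit of > 10000 nM in this assay, at which 2 of the 3 values shown sit. The difference between the cores of compound 2 and compound 3 is not broken down here.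

Compound 4 `COc1ccc(C(=O)c2sc(Nc3ccc(F)cc3)nc2N)cc1` arises from compound 3 by methoxy in place of hydrogen on an aromatic carbon. This is the same kind of change as from compound 2 to compound 1, but at a different place: here the methoxy enters para to a large group, whereas in compound 1 it enters ortho to a methoxy group, meta to a large group and meta to a methoxy group. Since compound 3 sits at a limit, the size of the step from it cannot be measured against the earlier one. In this assay compound 4 is expected to give about 10000 nM, within 2000 nM to 30000 nM, which is an expected step of a number no higher from compound 3 to compound 4 (the limit leaves the size open). This expectation rests on the fact that, a single methoxy short of compound 1, compound 2 still gives only a limit of the assay, > 10000 nM.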

Compound 4, half-maximal inhibitory concentration: > 10000 nM
Compound 4: no number, only a limit; the forecaster's own chance of this, stated with the estimate: 70%; the middle value lies on the limit itself.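

Compound 3 and compound 4 both sit at a limit of the assay, so no step between them can be read: the limit of > 10000 nM in this assay, at which 3 of the 4 values shown sit.

Left open is whether methoxy in place of hydrogen, para to a large group, changes the antiproliferative activity at all.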